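Series notes: from compound 2 to compound 3

A few compounds are considered here, and "the series" means these few. Any claim that something is new, unique, unknown or untested is made for them only; others in the source may bear on it.

Compound 1 `O=C(Nc1cccc(Cl)c1)C(Cl)Cl` has "not determined" (no result reported) in a functional assay on KB cells (Homo sapiens) for antiproliferative activity, read by MTT assay, with a stated time of 72 h (a higher number here means a weaker inhibitor, a lower number a stronger inhibitor), that is, no reported result. Going by the values given here, compound 2 `O=C(Nc1cccc(I)c1)C(Cl)Cl` gives 5250 nM in this assay and so stands as the only number in hand, compound 1 being the further entry without one. Compound 3 `O=C(Nc1cccc(C(F)(F)F)c1)C(Cl)Cl` differs from compound 2 by trifluoromethyl in place of iodo on an aromatic carbon. Among the compounds with values here, no step between measured compounds is available, so the size of this change in this assay cannot be read from the series itself. A step of a 1.3-fold higher number from compound 2 to compound 3 (0.12 log units; within the scatter) is expected, either none beyond the scatter or toward a slightly weaker inhibitor. Compound 3 is estimated at 7000 nM, within 2500 nM to 20000 nM.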

Compound 3, half-maximal inhibitory concentration: 8860 nM
For compound 3 the middle estimate is 1.3-fold (0.10 log units) below the measured one, and the stated range covers the measured number.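

In this assay, going by these compounds alone, the first readable step at this aromatic carbon is a 1.7-fold higher number from compound 2 to compound 3 (0.23 log units; within the scatter), for trifluoromethyl in place of iodo. The position thus carries either a group of 1 heavy atom or one of 4 heavy atoms, with no difference beyond the scatter between these two compounds. No measurement shown bears on the reason for this result.

Steps involving compound 1 cannot be read, as it has no number, so chloro stays uncompared with iodo and trifluoromethyl. Also open, on these data alone, is whether an amine, a carboxylic acid or a longer chain on this carbon would give a step beyond the scatter.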